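A few compounds are considered here, and "the series" means these few. Any claim that something is new, unique, unknown or untested is made for them only; others in the source may bear on it.

Measured so far, in a functional assay on HL-60 cells (Homo sapiens) for cytotoxicity, read by luminescence and CellTiter-Glo, with a stated time of 3 days; on this read-out lower numbers stand for stronger inhibition and higher numbers for weaker inhibition:

compound 1 `N#Cc1ccc(NC(=O)c2ccc(F)cc2O)cc1`: 1380 nM
compound 2 `O=C(Nc1ccc(C(F)(F)F)cc1)c1ccc(F)cc1O`: 680 nM
compound 3 `N#Cc1ccc(NC(=O)c2ccc3cccnc3c2O)c(C#N)c1`: 890 nM

Compound 1 gives the highest of the three numbers. Against compound 3 the gap is within the scatter, so the two cannot be ordered; against compound 2 the step is a 2.0-fold lower number from compound 1 to compound 2 (0.31 log units; beyond the scatter), a modest but real lowering, and this is the only single-point change in the set.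

Compound 4 `N#Cc1ccc(NC(=O)c2ccc(-c3ccccc3)cc2O)cc1` differs from compound 1 by phenyl in place of fluoro on an aromatic carbon. Among the compounds with values here, the change sits on the ring that carries the hydroxy group, whereas the one measured step, from compound 1 to compound 2, alters the group on the other ring; no measured pair shows what happens when fluoro gives way to phenyl on this position. The step from compound 1 to compound 2 therefore does not transfer to compound 4, and nothing in the data supports a direction for this assay here. Expectation: no step beyond the scatter, with a wide band in either direction for compound 4, i.e. a step of a 1.3-fold lower number from compound 1 to compound 4 (0.10 log units; within the scatter) is estimated. The expected value for compound 4 is 1100 nM, within 300 nM to 4500 nM.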

Compound 4, half-maximal inhibitory concentration: 700 nM
The estimate for compound 4 lay 1.6-fold (0.20 log units) above the measured number; measured number inside the range.
By their numbers in this assay, from the lowest: compounds 2, 4, 3 and 1 (each within the scatter of the next, the first and the last beyond it).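

In this assay, phenyl in place of fluoro on this aromatic carbon, para to a large group and meta to a hydroxy group, gives a 2.0-fold lower number from compound 1 to compound 4 (0.29 log units; within the scatter) and so leaves compound 1 and compound 4 unordered. Within the data shown here, this is the first reading at this position, and it shows that a group of 6 heavy atoms with a six-membered aromatic ring can stand where a single fluorine stood without a step beyond the scatter, though a real lowering of the number is not established. Nothing at hand speaks to the reason for this outcome.

The compounds shown leave open how an amine or a carboxylic acid on this aromatic carbon would read, and whether a longer chain in place of phenyl would also give no step beyond the scatter. Also open, from the compounds shown here alone, is whether the phenyl exchange would read the same alongside trifluoromethyl in place of cyano, the change that separates compound 2 from compound 1.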